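The source may report more compounds than this note shows. Statements on the series, on what has been measured and on what is new or still open speak of the compounds shown alone.

Series notes. In an ADME assay on BJ cells (Homo sapiens) for cytotoxicity, with a stated time of 72 h (on this read-out higher numbers stand for an effect only at larger amounts of compound and lower numbers for an effect already at smaller amounts), compound 1 `Cc1ccc(-c2nc3ccccc3s2)cc1NC(=O)c1cc([N+](=O)[O-])c(N2CCCCC2)cc1Cl` returns only an assay limit, > 25000 nM. Compound 2 `O=C(Nc1nc(-c2cccc(F)c2)cs1)c1cc([N+](=O)[O-])ccc1Cl` gives 24000 nM in this assay. Compound 3 `COc1ccc(-c2nc3ccccc3s2)cc1NC(=O)c1cc([N+](=O)[O-])ccc1Cl` likewise returns only a limit, > 25000 nM, and no number of its own. Compound 3 therefore stands at the limit of > 25000 nM in this assay, at which 2 of the 3 values shown sit, so its place among the shown numbers cannot be fixed beyond that limit. Compound 4 `O=C(Nc1cccc(-c2nc3ccccc3s2)c1)c1cc([N+](=O)[O-])ccc1Cl` remains to be measured in this assay. The change from compound 3 to compound 4 is hydrogen in place of methoxy on an aromatic carbon. Among the compounds with values here, no measured step mirrors this change. In this assay the expected step is a number no higher from compound 3 to compound 4 (the limit leaves the size open), none beyond the scatter. Compound 4 is expected to give about 25000 nM, within 8000 nM to 80000 nM, most probably again reported as a limit.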

Compound 4, half-maximal effective concentration: > 27000 nM
Compound 4: only a limit was reported (the forecaster's own chance of this, stated with the estimate: 65%); at least 1.0-fold (0.03 log units) between middle value and limit.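

Within the data shown here, compound 3 and compound 4 both return only limits in this assay; no step between them can be read. The compounds shown leave open whether hydrogen in place of methoxy shifts this read-out at all.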